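A Fluorine Enters the Phenyl Ring of Compound 1

The compounds below may be only part of what the source reports. "The series", "measured", "known", "first", "only" and "open" are said of these compounds alone.

Compound 1, `COc1cc2nc(N3CCCN(C(=O)N4CCOCC4)CC3)cc(N)c2c(-c2ccccc2)c1OC`, was tested in an ADME assay on microsomes from liver (Canis lupus familiaris) for protein binding, tested at 1 uM (on this read-out higher numbers stand for a larger free fraction and lower numbers for a smaller free fraction), where compound 1 gives 0.59. The only other result of this kind comes from compound 2, `COc1cc2nc(N3CCc4ncccc4C3)nc(N)c2c(-c2ncccn2)c1OC`, which in this assay gives 1; the two results sit within the usual scatter of each other, so the two compounds cannot be told apart on this read-out. Compound 3, `COc1cc2nc(N3CCCN(C(=O)N4CCOCC4)CC3)cc(N)c2c(-c2ccc(F)cc2)c1OC`, has not been measured. It differs from compound 1 in one place: fluoro in place of hydrogen on an aromatic carbon. Among the compounds with values here, no measured pair shows what such a change does here, so the expectation is a step from compound 1 to compound 3 of a 1.2-fold lower number from compound 1 to compound 3 (0.07 log units; within the scatter), a shift that stays within the scatter and means no real change. The unbound fraction of compound 3 in this assay is therefore estimated at 0.5, expected to fall between 0.33 and 0.75.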

Compound 3, unbound fraction: 0.602
Compound 3: the middle estimate sits 1.2-fold (0.08 log units) below what was measured; the range from low to high includes it.
By their numbers in this assay, from the lowest: compounds 1, 3 and 2 (each within the scatter of the next).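

Replacing hydrogen with fluoro on the aromatic carbon para to a large group, the change from phenyl to 4-fluorophenyl, gives in this assay a 1.0-fold higher number from compound 1 to compound 3 (0.01 log units; within the scatter) and so lies within the scatter. Within the data shown here, this is the first measured pair that differs in only one place, so it offers a direct reading: on this measure, the two compounds cannot be told apart, and this single fluoro leaves no detectable mark at this position. No available evidence explains this result.

From the compounds shown here alone, the pair speaks only for fluoro on this carbon, so it remains open whether an amine or a carboxylic acid in the same place would also leave the unbound fraction unmoved. Going by these compounds, it is equally open whether fluoro on another carbon of the same ring would behave like this one.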